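The compounds below may be only part of what the source reports. "The series", "measured", "known", "first", "only" and "open" are said of these compounds alone.

The measured compounds:
compound 1, `O=C(CCCCC1CCSS1)NCc1cn(CCCOc2ccc3ccc(=O)oc3c2)nn1`, gives 43.5%
compound 2, `CC(=O)c1cc2ccc(OCCCn3cc(CNC(=O)CCCCC4CCSS4)nn3)cc2oc1=O`, gives 40.7%
compound 3, `O=C(CCCCC1CCSS1)NCc1cn(CCCOc2ccc3cc(-c4ccc(Cl)cc4)c(=O)oc3c2)nn1`, gives 79.4%

All three were tested in a functional assay on PC-12 cells (Rattus norvegicus) for cytotoxicity, read by MTT assay, with stated times of 3 h and 2 h, tested at 50 uM; on this read-out lower numbers stand for a weaker effect and higher numbers for a stronger effect at the one concentration tested. Compound 3 stands highest of the three numbers: the step of a number 35.9 percentage points higher from compound 1 to compound 3 (beyond the scatter) and the step of a number 38.7 percentage points higher from compound 2 to compound 3 (beyond the scatter) are both large and beyond the scatter, whereas the step of a number 2.8 percentage points lower from compound 1 to compound 2 (within the scatter) stays within it. Compound 4, `O=C(CCCCC1CCSS1)NCc1cn(CCCOc2ccc3cc(-c4ccc(Cl)c(Cl)c4)c(=O)oc3c2)nn1`, differs from compound 3 by chloro in place of hydrogen on an aromatic carbon. Among the measured compounds shown here, no measured step adds a chloro to this ring. For the measured compounds named here, the only steps that touch this part of the shared core are a number 35.9 percentage points higher from compound 1 to compound 3 (beyond the scatter) and a number 38.7 percentage points higher from compound 2 to compound 3 (beyond the scatter), which put the 4-chlorophenyl in place and raised the number a great deal. Compound 4 keeps that group and adds a single chloro, so the expectation in this assay is a step no larger than the scatter, with no clear direction. Compound 4 is therefore expected to give about 80%, between 65% and 92%. This estimate means a step of a number 0.6 percentage points higher from compound 3 to compound 4 (within the scatter).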

Compound 4, a percentage reported as activity, at one concentration (the size of the read-out at that concentration, not a potency): 54.8%
Estimate against measurement, compound 4: 25.2 percentage points above, outside the stated range (below it).
By their numbers in this assay, from the lowest: compounds 2 and 1 (each within the scatter of the next); then compound 4; then compound 3.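

In this assay, among the compounds shown here, the earlier compounds showed only that putting the 4-chlorophenyl in place raises the number, whereas here a single added chloro on that ring, ortho to the first chloro group, changes the result on its own: a number 24.6 percentage points lower from compound 3 to compound 4 (beyond the scatter). The 3,4-dichlorophenyl still keeps part of the gain, with a number 11.3 percentage points higher from compound 1 to compound 4 (beyond the scatter) when it replaces hydrogen and a number 14.1 percentage points higher from compound 2 to compound 4 (beyond the scatter) when it replaces acetyl, so the result depends on the exact groups on this ring and not merely on an aryl group being present. Nothing measured here explains why the added chloro lowers the number.

On these data alone, only chloro has been seen at this place on the ring, so it remains open whether a methyl, a methoxy or an amine there would lower the number as well. As far as these compounds go, it also remains open whether the same step would appear at other concentrations.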